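Same Atoms, Different Double-Bond Geometry: Compound 3 to Compound 4

A few compounds are considered here, and "the series" means these few. Any claim that something is new, unique, unknown or untested is made for them only; others in the source may bear on it.

Measured compounds:
- Compound 1 `CC(=O)OC[C@H]1O[C@@H](n2cc(CN3C(=O)/C(=C/c4ccccc4)c4ccccc43)nn2)[C@H](OC(C)=O)[C@@H](OC(C)=O)[C@@H]1OC(C)=O`: > 100000 nM
- Compound 2 `CC(=O)OC[C@H]1O[C@@H](n2cc(CN3C(=O)/C(=C/c4ccc(C)cc4)c4ccccc43)nn2)[C@H](OC(C)=O)[C@@H](OC(C)=O)[C@@H]1OC(C)=O`: 73300 nM
- Compound 3 `CC(=O)OC[C@H]1O[C@@H](n2cc(CN3C(=O)/C(=C\C=C\c4ccccc4)c4ccccc43)nn2)[C@H](OC(C)=O)[C@@H](OC(C)=O)[C@@H]1OC(C)=O`: 25900 nM

In an ADME assay on NIH3T3 cells (Homo sapiens) for cytotoxicity, read by sulforhodamine B assay, with a stated time of 48 h (on this read-out lower numbers stand for stronger inhibition and higher numbers for weaker inhibition), compound 1 gives > 100000 nM, which is a limit of the assay rather than a number, namely (the limit of > 100000 nM in this assay, at which 1 of the 3 values shown sits). Compound 2 gives 73300 nM. Compound 3 gives 25900 nM, the lowest of the two numbers; its nearest neighbour, compound 2, sits higher by a gap beyond the scatter. Among the compounds with values here, the only step between two measured compounds that differ in one place is an at least 1.3-fold lower number from compound 1 to compound 2 (0.13 log units; that floor lies within the scatter).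

Compound 4 `CC(=O)OC[C@H]1O[C@@H](n2cc(CN3C(=O)/C(=C/C=C/c4ccccc4)c4ccccc43)nn2)[C@H](OC(C)=O)[C@@H](OC(C)=O)[C@@H]1OC(C)=O` differs from compound 3 as follows: the two compounds have the same atoms and bonds and differ only in configuration as drawn: 1 of 7 stereo elements differ; a double bond is drawn Z in compound 3 and E in compound 4. Within the data shown here, no measured step changes the geometry of a double bond, so the one step available does not bear on this change, and the measured values give no direction. The expected step is therefore none beyond the scatter, a 1.0-fold higher number from compound 3 to compound 4 (0.00 log units; within the scatter). Compound 4 is thus estimated at 26000 nM, within a range from 8000 nM to 85000 nM.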

Compound 4, half-maximal inhibitory concentration: 12300 nM
Estimate against measurement, compound 4: 2.1-fold (0.33 log units) above, and the stated range covers the measured number.
By their numbers in this assay, from the lowest: compound 4; then compound 3; then compound 2. At a limit, above all of these: compound 1.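

Changing only the geometry of this double bond gives a 2.1-fold lower number from compound 3 to compound 4 (0.32 log units; beyond the scatter) in this assay, so the drawn configuration at this position matters on its own, with no group added or removed: the fact that compounds 3 and 4 differ only in the configuration as drawn. Compared with the earlier compounds, the 2-phenylethenyl group of compound 4 gives a 6.0-fold lower number from compound 2 to compound 4 (0.78 log units; beyond the scatter) when it takes the place of 4-methylphenyl and an at least 8.1-fold lower number from compound 1 to compound 4 (0.91 log units; beyond the scatter) when it takes the place of phenyl. Compound 1 stands at a limit of the assay and not at a number, so that last step is only a floor: the limit of > 100000 nM in this assay, at which 1 of the 4 values shown sits.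

What lies behind the effect of the geometry cannot be told from these values. From the compounds shown here alone, it also remains open whether a longer chain with a further double bond, or an amine or a carboxylic acid on the phenyl of the 2-phenylethenyl group, would shift the number further.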